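Formyl on the amino group of a thiophene amide

The source may hold more compounds than are shown below. What is called first, only, known or untested is meant among the compounds shown, and "the series" means these compounds.

Measured compounds:
Compound 1 `CCN1CCc2c(sc(N)c2C(N)=O)C1`: in a functional assay (strain AB) with Danio rerio as the target, read by microscopy, with a stated time of 1 h (on this read-out lower numbers stand for an effect already at smaller amounts and higher numbers for an effect only at larger amounts of compound), compound 1 gives only a limit, > 25000 nM.
Compound 2 `CCN1CCc2c(sc(NC(=O)Nc3ccc(Cl)cc3)c2C#N)C1`: in this assay compound 2 gives only a limit, > 25000 nM.
Compound 3 `CCN1CCc2c(sc(NC(=O)Nc3ccc(Cl)cc3)c2C(=O)c2nnco2)C1`: in this assay compound 3 gives only a limit, > 25000 nM.

Compound 1 stands, like the other two, at the limit of > 25000 nM in this assay, at which 3 of the 3 values shown sit; no number is known for it, only the limit. Among the measured compounds shown here, the one pair that differs in a single place runs a step that the two limits leave unreadable from compound 2 to compound 3. Both of its ends are limits. Its size is not readable. That change also sits on a different part of the shared core than the change studied here, so it says nothing direct about it.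

Compound 4 `CCN1CCc2c(sc(NC=O)c2C(N)=O)C1` carries formyl in place of hydrogen on a nitrogen on an aromatic ring. For the measured compounds named here, no measured step involves this amide-bearing core or a formyl group, so there is nothing to read a direction from; compound 1 is a limit, and a small group added to a compound at the limit is expected, most often, to stay at the limit. Compound 4 is therefore expected to give about 30000 nM, with a range from 8000 nM to 120000 nM. This expectation means a step that the limit leaves unreadable from compound 1 to compound 4, in practice no readable step.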

Compound 4, half-maximal effective concentration: > 25000 nM
Compound 4: no number, only a limit; the forecaster's own chance of this, stated with the estimate: 85%; the middle value does not contradict the limit.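

Among the compounds shown here, compound 4 gives only a limit, as compound 1 does, and no step between the two can be read. The compounds shown leave open whether any change on the shared core gives a measurable value in this assay, and all of them sit at one limit: the limit of > 25000 nM in this assay, at which 4 of the 4 values shown sit.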